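From Nitro to Bromo in an Antiproliferative Series

This account rests on a few compounds, and the source may have more. Where it says the series, first, only, none or still open, it means among the compounds named here.

Of the compounds shown here, three sharing one core have been measured in a functional assay on QG-56 cells (Homo sapiens) for antiproliferative activity; on this read-out higher numbers stand for weaker inhibition and lower numbers for stronger inhibition. Compound 1 (`Cn1cncc1C(O)(c1ccc([N+](=O)[O-])cc1)c1cc2cc([N+](=O)[O-])cc(-c3ccccc3)c2o1`) gives 547 nM, the highest of the three numbers and so the weakest inhibition among them. Compound 2 (`Cn1cncc1C(O)(c1ccc(C#N)cc1)c1cc2cc([N+](=O)[O-])cc(-c3ccccc3F)c2o1`) gives 89.5 nM and compound 3 (`Cn1cncc1C(O)(c1ccc(C#N)cc1)c1cc2cc(C#N)cc(-c3ccccc3)c2o1`) gives 14.5 nM, both lower than compound 1 by more than the usual scatter. For the measured compounds named here, neither of these two keeps the 4-nitrophenyl group of compound 1, but each also differs from it elsewhere, so no measured pair isolates that group.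

The next compound to be tested is compound 4 (`Cn1cncc1C(O)(c1ccc(Br)cc1)c1cc2cc([N+](=O)[O-])cc(-c3ccccc3)c2o1`), which keeps everything in compound 1 except for one substituent. The change is bromo in place of nitro on an aromatic carbon, turning 4-nitrophenyl into 4-bromophenyl. With no direct comparison available, the expectation rests on a weak hint: the lower numbers come from compounds without the 4-nitrophenyl group, compound 2 at 89.5 nM and compound 3 at 14.5 nM. A modest move towards stronger inhibition in this assay is therefore expected, far smaller than the gaps these two compounds show, and the estimated step is a 2.2-fold lower number from compound 1 to compound 4 (0.34 log units; beyond the scatter). For compound 4 the estimated value is 250 nM. The expected range for compound 4 runs from 80 nM to 800 nM.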

Compound 4, half-maximal inhibitory concentration: 1480 nM
Compound 4: the middle estimate sits 5.9-fold (0.77 log units) below what was measured; the measured number lies above the stated range.
By their numbers in this assay, from the lowest: compound 3; then compound 2; then compound 1; then compound 4.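

In this assay, for the compounds shown here, the step of a 2.7-fold higher number from compound 1 to compound 4 (0.43 log units; beyond the scatter) is the first comparison in this set that isolates a single change, and it runs towards weaker inhibition, not stronger. At this position, on an aromatic carbon para to a large group, giving up nitro for bromo with everything else held constant does not lower the number, so the absence of the 4-nitrophenyl group is not enough on its own to account for the lower numbers of compound 2 and compound 3, which also differ from compound 1 elsewhere. Nothing available on these compounds explains the direction or size of this step.

From the compounds shown here alone, only two substituents have been compared directly at this position, so it remains open how a nitrile, an amine or a methoxy group would rank there against nitro and bromo in an otherwise unchanged compound. Going by these compounds, it also remains open whether the change from nitro to bromo would run the same way in compounds carrying a nitrile on the shared core or a fluorine on its phenyl group, as compound 3 and compound 2 do.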